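The source may report more compounds than this note shows. Statements on the series, on what has been measured and on what is new or still open speak of the compounds shown alone.

Measured so far in a functional assay on RAW264.7 cells (Mus musculus), read by fluorescence; a lower number here means a stronger inhibitor, a higher number a weaker inhibitor:
- compound 1 `CCOC(=O)C1=CCCCC1S(=O)(=O)Cc1ccc(F)cc1Cl`: 10 nM; 10000 nM; 5.7 nM (3 entries)
- compound 2 `CC(C)OC(=O)C1=CCCCC1S(=O)(=O)Cc1ccc(F)cc1Cl`: 100 nM
- compound 3 `O=S(=O)(Cc1ccc(F)cc1Cl)C1CCCC=C1CO`: > 10000 nM, a limit of this assay, not a number

Compound 3 stands at the limit only, as the limit of > 10000 nM in this assay, at which 1 of the 3 values shown sits, shows, with one further entry giving no single number. Compound 4 `CCCC(=O)C1=CCCCC1S(=O)(=O)Cc1ccc(F)cc1Cl` differs from compound 3 by propylcarbonyl in place of hydroxymethyl on a double-bonded ring carbon. Going by the values given here, the one measured step that bears on this place is an at least 100-fold higher number from compound 2 to compound 3 (2.00 log units; beyond the scatter), which runs in the opposite direction: replacing isopropoxycarbonyl by hydroxymethyl removed measurable inhibition. Putting a carbonyl-bearing group back at that carbon is expected to reverse much of that loss. The wide spread of entries for compound 1, see (the several entries of compound 1 in this assay, 10 nM; 10000 nM; 5.7 nM (3 entries)), limits how sharply this can be set. The expected step is an at least 66-fold lower number from compound 3 to compound 4 (1.82 log units; beyond the scatter). Compound 4 is estimated at 150 nM, between 20 nM and 3000 nM.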

Compound 4, half-maximal inhibitory concentration: 11 nM
Beside the measured number, compound 4's estimate is 14-fold (1.13 log units) above it, outside the stated range (below it).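

Propylcarbonyl on the double-bonded ring carbon restores strong inhibition in this assay, with an at least 900-fold lower number from compound 3 to compound 4 (2.95 log units; beyond the scatter); one end of this step is a limit of the assay, so its true size remains open. An isopropoxy group on the carbonyl carbon is not required for inhibition, and propyl in its place gives a 9.1-fold lower number from compound 2 to compound 4 (0.96 log units; beyond the scatter). Compound 1 cannot be placed firmly against compound 4, given its spread of entries: the several entries of compound 1 in this assay, 10 nM; 10000 nM; 5.7 nM (3 entries)

Still open, from the compounds shown here alone, is whether the carbonyl or the added chain accounts for the gain in compound 4. Going by these compounds, it is also open whether a carboxylic acid, an amide or a longer chain at this carbon would hold this level of inhibition.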